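Pyrimidin-2-yl in place of pyridin-2-yl: working notes

The source may report more compounds than this note shows. Statements on the series, on what has been measured and on what is new or still open speak of the compounds shown alone.

Values in an ADME assay on NIH3T3 cells (Mus musculus) for cytotoxicity, read by MTT assay, with a stated time of 24 h; on this read-out lower numbers stand for stronger inhibition and higher numbers for weaker inhibition
compound 1 `CN1CCN(C(=S)SCC(=O)Nc2ccc(S(N)(=O)=O)cc2)CC1` gives 14500 nM
compound 2 `CN(C)CCCN1CCN(C(=S)SCC(=O)Nc2ccc(S(N)(=O)=O)cc2)CC1` gives > 1000000 nM as a limit
compound 3 `NS(=O)(=O)c1ccc(NC(=O)CSC(=S)N2CCN(c3ccccn3)CC2)cc1` gives 18500 nM

Going by the values given here, only two of these values are true numbers, and the step between them is a 1.3-fold higher number from compound 1 to compound 3 (0.11 log units; within the scatter) on this read-out. The value of compound 2 is a limit. The two large steps, an at least 68-fold higher number from compound 1 to compound 2 (1.83 log units; beyond the scatter) and an at least 54-fold lower number from compound 2 to compound 3 (1.73 log units; beyond the scatter), both run through that limit and concern the 3-(dimethylamino)propyl compound only.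

Compound 4 `NS(=O)(=O)c1ccc(NC(=O)CSC(=S)N2CCN(c3ncccn3)CC2)cc1` has pyrimidin-2-yl in place of pyridin-2-yl on an amine nitrogen in a ring with the rest of compound 3 unchanged. Among the compounds with values here, no measured step swaps one aromatic ring for another. The closest guide is the exchange of methyl for pyridin-2-yl, a 1.3-fold higher number from compound 1 to compound 3 (0.11 log units; within the scatter), so no step beyond the scatter is expected in this assay. The expected step is a 1.0-fold lower number from compound 3 to compound 4 (0.01 log units; within the scatter) by this estimate. For compound 4 the estimated value is 18000 nM with an expected range from 7000 nM to 45000 nM as the upper end.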

Compound 4, half-maximal inhibitory concentration: 16500 nM
Compound 4: the middle estimate sits 1.1-fold (0.04 log units) above what was measured; low and high end bracket the measured number.
By their numbers in this assay, from the lowest: compounds 1, 4 and 3 (each within the scatter of the next). At a limit, above all of these: compound 2.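

The exchange of one aromatic ring for another on this amine nitrogen in a ring can now be read in this assay: a 1.1-fold lower number from compound 3 to compound 4 (0.05 log units; within the scatter), so a ring with 2 hetero atoms and one with 1 hetero atom are not told apart here. With a 1.1-fold higher number from compound 1 to compound 4 (0.06 log units; within the scatter), methyl, pyridin-2-yl and pyrimidin-2-yl on this nitrogen all lie within the scatter of one another, whether the group is a small alkyl or an aromatic ring. Compound 2 stays apart, with an at least 60-fold lower number from compound 2 to compound 4 (1.78 log units; beyond the scatter), and that step runs through a limit: the limit of > 1000000 nM in this assay, at which 1 of the 4 values shown sits.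

Open, going by these compounds, is whether the departure of compound 2 belongs to the terminal dimethylamino group or to the chain, which a 3-hydroxypropyl group on this nitrogen would help separate. Also open, on these data alone, is whether a phenyl ring, with no ring nitrogen, would stay within the same scatter.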